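The source may report more compounds than this note shows. Statements on the series, on what has been measured and on what is new or still open speak of the compounds shown alone.

Measured in a functional assay on L1210/0 cells (Mus musculus) for antiproliferative activity, read by MTT assay, with a stated time of 72 h; a lower number here means a stronger inhibitor, a higher number a weaker inhibitor:
- Compound 1 `O=C1O/C(=C\Cn2cnc3c(F)nc(F)c(Cl)c32)C(OCc2ccccc2)=C1OCc1ccccc1` stands as "not determined" (no result reported) and has no number
- Compound 2 `O=C1O/C(=C\Cn2cnc3ccn(C/C=C4\OC(=O)C(OCc5ccccc5)=C4OCc4ccccc4)c3c2=O)C(OCc2ccccc2)=C1OCc1ccccc1` gives 4500 nM
- Compound 3 `O=C1O/C(=C\Cn2cnc3cc[nH]c3c2=O)C(OCc2ccccc2)=C1OCc1ccccc1` gives 28000 nM

Of the two numbers available, compound 3 (28000 nM) has the higher one, so it is the weaker inhibitor of the pair. Compound 2 (4500 nM) lies lower by more than the usual scatter of repeated measurements. Compound 1 cannot be placed on this scale.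

Compound 4 `O=C1O/C(=C\Cn2cnc3cncc(Br)c32)C(OCc2ccccc2)=C1OCc1ccccc1` has not yet been measured. It differs from compound 3 at one place, on a saturated chain carbon bound to a double-bonded chain carbon (a group of 10 heavy atoms (6 carbon, 3 nitrogen, 1 bromine; one five-membered aromatic ring with 2 hetero atoms, one six-membered aromatic ring with 1 hetero atom) in place of a group of 10 heavy atoms (6 carbon, 3 nitrogen, 1 oxygen; one five-membered aromatic ring with 1 hetero atom, one six-membered aromatic ring with 2 hetero atoms), on a saturated chain carbon bound to a double-bonded chain carbon). The entering group brings a bromine and leaves no hydrogen-bond donor. Among the compounds with values here, no measured pair isolates this exchange, so any expectation rests on thin evidence.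

Compound 3 (28000 nM) already sits at the high end, and compound 2 (4500 nM) shows that a lower number is reachable with the shared core. The expected change is therefore modest and downward, toward a stronger inhibitor, as a 3.5-fold lower number from compound 3 to compound 4 (0.54 log units; beyond the scatter) in the estimate. A result within the scatter of compound 3 would not surprise. For compound 4 in this assay the estimated value is (8000 nM), with an expected range from (2000 nM) to (28000 nM).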

Compound 4, half-maximal inhibitory concentration: 6800 nM
Beside the measured number, compound 4's estimate is 1.2-fold (0.07 log units) above it, and the stated range covers the measured number.
By their numbers in this assay, from the lowest: compounds 2 and 4 (each within the scatter of the next); then compound 3.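

In this assay, within the data shown here, the exchange on a saturated chain carbon bound to a double-bonded chain carbon gives a 4.1-fold lower number from compound 3 to compound 4 (0.61 log units; beyond the scatter) and is the only single-place comparison available here, with a step beyond the usual scatter. It shows that activity in this assay is kept, and the number falls, when the group with 1 oxygen, 1 hydrogen-bond donor and 1 double bond outside aromatic rings gives way to the group with 1 bromine and 0 hydrogen-bond donors. No measured property of either group is at hand to account for this step.

The exchange alters several features at once, including the bromine, the oxygen, the hydrogen-bond donor and the spread of hetero atoms over the two rings, so the compounds shown cannot assign the step to any one of them. From the compounds shown here alone, it also remains open whether a methyl group or an amine in place of the bromine would keep a number like that of compound 4 6800 nM in this assay on the same shared core.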